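The source may hold more compounds than are shown below. What is called first, only, known or untested is meant among the compounds shown, and "the series" means these compounds.

Among the measured compounds shown here, compound 2 `CCCCCCCC/C=C\CCCCCCC(=O)c1ncco1` is the only compound that gives a number in an assay on isolated protein for inhibition of Fatty-acid amide hydrolase 1 (Homo sapiens) (a lower number here means a stronger inhibitor, a higher number a weaker inhibitor), and in this assay compound 2 gives 17 nM. Compound 1 `CCCCCCCC/C=C\CCCCCCC(=O)c1nccn1C` reaches only a limit in this assay, > 100000 nM. The step of an at least 5800-fold lower number from compound 1 to compound 2 (3.76 log units; beyond the scatter) is therefore bounded by the limit of > 100000 nM in this assay, at which 1 of the 2 values shown sits. Compound 3 `CCCCCCCC/C=C\CCCCCCC(=O)c1cccnn1` carries the change (pyridazin-3-yl in place of 1,3-oxazol-2-yl on a carbonyl carbon). For the measured compounds named here, the one measured step concerns the same carbonyl carbon but exchanges a different ring, so it gives no size for this new change. Compound 3 is expected to give 50 nM, between 10 nM and 300 nM, a step of a 2.9-fold higher number from compound 2 to compound 3 (0.47 log units; beyond the scatter) expected to stay within the scatter.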

Compound 3, inhibition constant: 130 nM
Compound 3: the middle estimate sits 2.6-fold (0.41 log units) below what was measured; measured number inside the range.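

In this assay, a six-membered aromatic ring on the carbonyl carbon still gives a measurable number, so this position is not confined to a five-membered ring. Exchanging 1,3-oxazol-2-yl for pyridazin-3-yl nevertheless gives a 7.6-fold higher number from compound 2 to compound 3 (0.88 log units; beyond the scatter). The pyridazin-3-yl ring also compares well with 1-methyl-1H-imidazol-2-yl, with an at least 760-fold lower number from compound 1 to compound 3 (2.88 log units; beyond the scatter), though this size is only a bound set by a limit: the limit of > 100000 nM in this assay, at which 1 of the 3 values shown sits.

From the compounds shown here alone, it remains open whether a thiazol-2-yl, pyridin-2-yl or phenyl ring on the same carbonyl carbon would stand nearer compound 2 or compound 3. Going by these compounds, it is also open whether a longer chain would change the size of these steps.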